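Carbamate aryl change on the shared core: compound 3 to compound 4

This account rests on a few compounds, and the source may have more. Where it says the series, first, only, none or still open, it means among the compounds named here.

The series keeps one core and varies the aryl group on the carbamate nitrogen. Compound 1 `COc1ccccc1NC(=O)Oc1cc(=O)n(CCCO)c2c1CC(CC=C(C)C)C(C)(C)C2` gives 71.1% in a functional assay on PANC-1 cells (Homo sapiens) for inhibition, read by MTT assay, with a stated time of 24 h, tested at 10 uM; a lower number here means less inhibition, a higher number more inhibition at the concentration tested (going by the name of the read-out). Compound 2 `CC(C)=CCC1Cc2c(OC(=O)Nc3ccccc3F)cc(=O)n(CCCO)c2CC1(C)C` gives 52.3%. Compound 3 `CC(C)=CCC1Cc2c(OC(=O)Nc3ccc(F)c(F)c3)cc(=O)n(CCCO)c2CC1(C)C` gives 76.7%, the highest of the three numbers; its gap to compound 1 lies within the scatter, so these two numbers are level, and only the gap to compound 2 is beyond it, so only against compound 2 is the number of compound 3 higher.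

Compound 4 `CC(C)=CCC1Cc2c(OC(=O)Nc3ccc(Cl)c(Cl)c3)cc(=O)n(CCCO)c2CC1(C)C` differs from compound 3 as follows: 3,4-dichlorophenyl in place of 3,4-difluorophenyl on an amide-type nitrogen. Within the data shown here, no measured step swaps fluorine for chlorine on the aryl group, so no step bears on it directly. The aryl changes on the same nitrogen that are measured ran a number 18.8 percentage points lower from compound 1 to compound 2 (beyond the scatter), a number 5.6 percentage points higher from compound 1 to compound 3 (within the scatter) and a number 24.4 percentage points higher from compound 2 to compound 3 (beyond the scatter), so such swaps have moved the read-out by at most modest amounts.

With the substitution pattern kept and only the halogen changed, the expected step is a number 1.3 percentage points higher from compound 3 to compound 4 (within the scatter), within the scatter. Compound 4 is therefore estimated at 78%, with a range from 60% to 92%.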

Compound 4, a percentage reported as inhibition, at one concentration (the size of the read-out at that concentration, not a potency): 61.4%
Estimate against measurement, compound 4: 16.6 percentage points above; the measured number falls inside the stated range.
By their numbers in this assay, from the lowest: compounds 2, 4, 1 and 3 (each within the scatter of the next, the first and the last beyond it).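

The step in this assay shows that the halogen alone matters on the amide-type nitrogen: with the substitution pattern kept, 3,4-dichlorophenyl in place of 3,4-difluorophenyl gives a number 15.3 percentage points lower from compound 3 to compound 4 (beyond the scatter). Earlier steps changed the position of the substituents or the kind of substituent, whereas this one separates two halogens on the same pattern. Against the other two aryl groups, 3,4-dichlorophenyl reads as a number 9.1 percentage points higher from compound 2 to compound 4 (within the scatter) and a number 9.7 percentage points lower from compound 1 to compound 4 (within the scatter), so it sits level with both, even though those two are themselves separated by a number 18.8 percentage points lower from compound 1 to compound 2 (beyond the scatter).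

Nothing available explains why the halogen swap moves the number. On these data alone, whether an unsubstituted phenyl, or an aryl group carrying bromine or a nitrile, would read closer to 3,4-difluorophenyl or to 3,4-dichlorophenyl remains open.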